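The compounds below may be only part of what the source reports. "The series", "measured", "known", "first", "only" and "open" are said of these compounds alone.

Working notes on the series. In a functional assay on OVCAR-8 cells (Homo sapiens) for antiproliferative activity (on this read-out higher numbers stand for weaker inhibition and lower numbers for stronger inhibition), compound 1 (`Cn1ncc(Cl)c1-c1cc(C(=O)N[C@@H]2CN[C@H](CC(O)CO)C[C@H]2c2ccc(Cl)c(Cl)c2)oc1Cl`) gives 1610 nM and compound 2 (`C=CC[C@@H]1C[C@@H](c2ccc(Cl)c(Cl)c2)[C@H](NC(=O)c2cc(-c3c(Cl)cnn3C)c(Cl)o2)CN1`) gives 990 nM on the shared core. Among the measured compounds shown here, compound 2 therefore stands within the scatter of compound 1, the only other measured compound.

The step under consideration leads to compound 3 (`CN(C)CC[C@@H]1C[C@@H](c2ccc(Cl)c(Cl)c2)[C@H](NC(=O)c2cc(-c3c(Cl)cnn3C)c(Cl)o2)CN1`): (dimethylamino)methyl in place of vinyl on a saturated chain carbon bound to a saturated ring carbon (that is, (dimethylamino)methyl in place of vinyl on a saturated chain carbon bound to a saturated ring carbon).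

For the measured compounds named here, the one measured step at this place (a 1.6-fold lower number from compound 1 to compound 2 (0.21 log units; within the scatter)) stays within the scatter, but it involves a different pair of groups. Going by the values given here, no measured compound carries the new amine, so the evidence is thin and the range must stay wide. In this assay no step beyond the scatter is expected, in either direction. The estimated step is a 1.0-fold higher number from compound 2 to compound 3 (0.00 log units; within the scatter) for now. Compound 3 is expected at 1000 nM within an estimated range of 350 nM to 2900 nM on this read-out.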

Compound 3, half-maximal inhibitory concentration: 1510 nM
The estimate for compound 3 lay 1.5-fold (0.18 log units) below the measured number; measured number inside the range.
By their numbers in this assay, from the lowest: compounds 2, 3 and 1 (each within the scatter of the next).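

In this assay, the step from vinyl to (dimethylamino)methyl on a saturated chain carbon bound to a saturated ring carbon is a 1.5-fold higher number from compound 2 to compound 3 (0.18 log units; within the scatter) and adds a nitrogen at this place without a step beyond the scatter. The step from 1,2-dihydroxyethyl to the same amine is a 1.1-fold lower number from compound 1 to compound 3 (0.03 log units; within the scatter) and also stays within the scatter, so vinyl, 1,2-dihydroxyethyl and (dimethylamino)methyl give no separation at this place in this assay on the shared core. No measurement on hand explains these steps.

On these data alone, whether a carboxylic acid, a morpholine or a longer chain ending in an amine at this place would move the number beyond the scatter remains open. Also open, as far as these compounds go, is whether a plain hydrogen at this place would give a number within the scatter of these three compounds.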